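Moving one chloro group on the nitrogen-bound ring

The source may hold more compounds than are shown below. What is called first, only, known or untested is meant among the compounds shown, and "the series" means these compounds.

In a functional assay on A549 cells (Homo sapiens) for inhibition, read by MTT assay, with a stated time of 72 h (on this read-out lower numbers stand for stronger inhibition and higher numbers for weaker inhibition), compound 1 (`Cc1cc2occ(-c3nc(-c4ccccc4)c(-c4ccccc4)n3-c3ccc(Cl)c(Cl)c3)c(=O)c2cc1Cl`) gives 6250 nM, compound 2 (`Cc1cccc(-n2c(-c3coc4cc(C)c(Cl)cc4c3=O)nc(-c3ccccc3)c2-c2ccccc2)c1`) gives 12500 nM and compound 3 (`Cc1cc2occ(-c3nc(-c4ccccc4)c(-c4ccccc4)n3-c3ccc(Cl)cc3)c(=O)c2cc1Cl`) gives 12500 nM. Compound 3 is thus level with compound 2, and all three lie within the usual scatter of one another. Compound 4 (`Cc1cc2occ(-c3nc(-c4ccccc4)c(-c4ccccc4)n3-c3ccccc3Cl)c(=O)c2cc1Cl`) has the same atoms as compound 3, joined differently: 2-chlorophenyl in place of 4-chlorophenyl on an aromatic nitrogen. Earlier changes to the group on that nitrogen were small: a 2.0-fold higher number from compound 1 to compound 2 (0.30 log units; within the scatter), a 2.0-fold higher number from compound 1 to compound 3 (0.30 log units; within the scatter) and no change at the digits printed from compound 2 to compound 3 (within the scatter). None of them tests the 2-chlorophenyl group, so the expected range stays wide. No step beyond the scatter is expected, with an estimated no change at the digits printed from compound 3 to compound 4 (within the scatter). For compound 4 the estimated value is 12500 nM, with an expected range of 5000 nM to 30000 nM.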

Compound 4, half-maximal inhibitory concentration: 12500 nM
Estimate against measurement, compound 4: no gap at the digits printed; the range from low to high includes it.
By their numbers in this assay, from the lowest: compounds 1, 2, 3 and 4 (each within the scatter of the next).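

Swapping 4-chlorophenyl for 2-chlorophenyl gives no change at the digits printed from compound 3 to compound 4 (within the scatter) here, so these two placements of the chloro group on this ring cannot be told apart. The new group also stays close to the others on that nitrogen, with no change at the digits printed from compound 2 to compound 4 (within the scatter) and a 2.0-fold higher number from compound 1 to compound 4 (0.30 log units; within the scatter) as the remaining comparisons. No evidence at hand explains this flat result. Still open, as far as these compounds go, is whether a carboxylic acid or an amine on this ring would give a step beyond the scatter.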